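The source may report more compounds than this note shows. Statements on the series, on what has been measured and on what is new or still open speak of the compounds shown alone.

In an assay on isolated protein with Bile acid receptor (Homo sapiens) as the target (a lower number here means that less compound is needed, a higher number that more compound is needed for the effect), compound 3 `COC(=O)/C=C/c1cccc(N(Cc2ccc(/C=C/c3scnc3C)cc2)C(=O)C(C)C)c1` gives 228 nM. Compound 2 `COC(=O)/C=C/c1cccc(N(Cc2ccc(/C=C/c3scnc3C)cc2)C(=O)C2CCCCC2)c1` gives 227 nM and compound 1 `COC(=O)/C=C/c1cccc(N(Cc2ccc(/C=C/c3ccccc3F)cc2)C(=O)NC(C)C)c1` gives 431 nM; both lie within the scatter of compound 3, so no order among the three can be read. For the measured compounds named here, the only measured step, a 1.0-fold higher number from compound 2 to compound 3 (0.00 log units; within the scatter), swaps the group on the carbonyl carbon and leaves the number where it was. Compound 4 `COC(=O)/C=C/c1cccc(N(Cc2ccc(-c3ccc(OC(F)(F)F)cc3)cc2)C(=O)C(C)C)c1` differs from compound 3 elsewhere: 4-(trifluoromethoxy)phenyl in place of 2-(4-methyl-1,3-thiazol-5-yl)ethenyl on an aromatic carbon. Going by the values given here, no measured step touches this part of the molecule, and compound 1 differs from compound 3 both here and at the carbonyl, so its value gives no isolated reading. The expected step, a 1.3-fold higher number from compound 3 to compound 4 (0.12 log units; within the scatter), is therefore set at none beyond the scatter, with a wide range. Compound 4 is estimated at 300 nM, between 100 nM and 1000 nM.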

Compound 4, half-maximal effective concentration: 219 nM
Compound 4: middle estimate off by 1.4-fold (0.14 log units), on the high side, and the stated range covers the measured number.
By their numbers in this assay, from the lowest: compounds 4, 2, 3 and 1 (each within the scatter of the next).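

In this assay, the aromatic carbon para to a large group takes 4-(trifluoromethoxy)phenyl in place of 2-(4-methyl-1,3-thiazol-5-yl)ethenyl with a 1.0-fold lower number from compound 3 to compound 4 (0.02 log units; within the scatter). The five-membered aromatic ring and the double bond outside aromatic rings are therefore both dispensable here, as a six-membered aromatic ring of carbon only leaves the number within the scatter. No measurement of any property of these groups accompanies this result. Open, going by these compounds, is how an amine or a carboxylic acid on this aromatic carbon would read, and whether 4-(trifluoromethoxy)phenyl behaves the same with cyclohexyl on the carbonyl carbon.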